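A Fluorine Added to a Benzothiazole Nucleotide

This account rests on a few compounds, and the source may have more. Where it says the series, first, only, none or still open, it means among the compounds named here.

Going by the values given here, compound 2 `O=P(O)(O)OP(=O)(O)OP(=O)(O)OC[C@H]1O[C@@H](c2nc3ccccc3s2)[C@H](O)[C@@H]1O` gives the lower of the two numbers measured so far in a functional assay for agonist activity at P2Y purinoceptor 2 (Homo sapiens), read by FLIPR (on this read-out lower numbers stand for an effect already at smaller amounts and higher numbers for an effect only at larger amounts of compound), where compound 2 gives 22 nM. Among the compounds with values here, its only neighbour, compound 1 `Cc1ccc2oc([C@@H]3O[C@H](COP(=O)(O)OP(=O)(O)OP(=O)(O)O)[C@@H](O)[C@H]3O)nc2c1`, gives 390 nM in this assay; the step of an 18-fold lower number from compound 1 to compound 2 (1.25 log units; beyond the scatter) swaps the whole ring system attached to the saturated ring carbon. Compound 3 `O=P(O)(O)OP(=O)(O)OP(=O)(O)OC[C@H]1O[C@@H](c2nc3cc(F)ccc3s2)[C@H](O)[C@@H]1O` keeps everything in compound 2 and adds a single atom: fluoro in place of hydrogen on an aromatic carbon. Within the data shown here, no measured pair shows a fluoro added to an otherwise unchanged compound, so the one recorded step, which replaces 5-methyl-1,3-benzoxazol-2-yl with 1,3-benzothiazol-2-yl, says little about this smaller change. Among the measured compounds shown here, with no comparable precedent, the step of a 1.1-fold higher number from compound 2 to compound 3 (0.06 log units; within the scatter) is expected to lie within the scatter. Compound 3 is therefore estimated at 25 nM in this assay, with a range from 8 nM to 80 nM.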

Compound 3, half-maximal effective concentration: 3 nM
Beside the measured number, compound 3's estimate is 8.3-fold (0.92 log units) above it; measured number below the stated range.
By their numbers in this assay, from the lowest: compound 3; then compound 2; then compound 1.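

Up to now the only step in this assay swapped a whole ring system, whereas a 7.3-fold lower number from compound 2 to compound 3 (0.87 log units; beyond the scatter) comes from one fluoro in place of hydrogen, so a single added heavy atom on this aromatic carbon is enough to move the number beyond the scatter. Taken together with the change of ring system, the 5-fluoro-1,3-benzothiazol-2-yl group gives a 130-fold lower number from compound 1 to compound 3 (2.11 log units; beyond the scatter) and places compound 3 lowest of the three compounds. Nothing available here explains why this one atom has so clear an effect.

The compounds shown do not tell whether this gain belongs to fluoro alone or would also appear with chloro, methyl or methoxy on the same carbon. They also leave open how a fluoro would behave on the other aromatic carbons of this ring.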